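Pyridinyl for Tolyl on an Alkyne-Capped Weak Binder

The source may report more compounds than this note shows. Statements on the series, on what has been measured and on what is new or still open speak of the compounds shown alone.

Of the compounds shown here, two sharing one bicyclic lactam core have been tested in an assay on HEK293 cells for displacement of a labelled ligand from metabotropic glutamate receptor 5 (Homo sapiens), with a stated time of 2 h; a lower number here means a stronger inhibitor, a higher number a weaker inhibitor. Compound 1 `CC(C)N1CCc2nc(C#Cc3cccnc3)ccc2C1=O` carries an isopropyl group on the amide nitrogen and a pyridin-3-yl group at the far end of the alkyne; in this assay compound 1 gives 19600 nM. Compound 2 `Cc1ccc(C#Cc2ccc3c(n2)CCN(C2CCCCC2)C3=O)cc1` instead carries a cyclohexyl group on the amide nitrogen and a 4-methylphenyl group at the far end of the alkyne; in this assay compound 2 gives 27200 nM. Of the two numbers, that of compound 2 is the higher, but the gap to compound 1 lies within the usual scatter, so the two cannot be told apart.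

Compound 3 `O=C1c2ccc(C#Cc3cccnc3)nc2CCN1C1CCCCC1` keeps the cyclohexyl group of compound 2 and takes the alkyne cap of compound 1: the change is pyridin-3-yl in place of 4-methylphenyl on a triple-bonded carbon. Among the measured compounds shown here, no pair of measured compounds isolates this change. Compound 1 already shows that the pyridin-3-yl cap sits in the same weak range as compound 2, so no step beyond the scatter is expected in this assay. For compound 3 the estimated value in this assay is 22000 nM, with a range of 8000 nM to 60000 nM, meaning an expected step of a 1.2-fold lower number from compound 2 to compound 3 (0.09 log units; within the scatter).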

Compound 3, inhibition constant: 15600 nM
Compound 3: the middle estimate sits 1.4-fold (0.15 log units) above what was measured, and the stated range covers the measured number.
By their numbers in this assay, from the lowest: compounds 3, 1 and 2 (each within the scatter of the next).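

With the cyclohexyl group held fixed, the exchange of 4-methylphenyl for pyridin-3-yl on a triple-bonded carbon can now be read on its own in this assay as a 1.7-fold lower number from compound 2 to compound 3 (0.24 log units; within the scatter) and, despite the hydrogen-bond acceptor that pyridin-3-yl brings and 4-methylphenyl lacks, it gives no difference that can be told from the scatter. The same set also isolates the group on the amide-type nitrogen in a ring for the first time: with the pyridin-3-yl cap held fixed, cyclohexyl in place of isopropyl gives a 1.3-fold lower number from compound 1 to compound 3 (0.10 log units; within the scatter) and is likewise indistinguishable, so neither single change among these three compounds moves the number beyond the scatter. Nothing measured on these compounds offers an explanation for this flat result.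

The compounds shown leave open whether any group at this end of the alkyne, such as pyridin-2-yl or 3-chlorophenyl, would give a step beyond the scatter. They also leave open whether a methyl group or a benzyl group on the amide nitrogen would do so.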